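Halogen swap on the amide aryl and cytotoxicity

A few compounds are considered here, and "the series" means these few. Any claim that something is new, unique, unknown or untested is made for them only; others in the source may bear on it.

Compound 1, `O=C(Nc1ccccc1F)c1ccc2cccc(O)c2n1`: in an ADME assay on THP-1 cells (Homo sapiens) for cytotoxicity, read by WST assay, with a stated time of 24 h (on this read-out lower numbers stand for stronger inhibition and higher numbers for weaker inhibition), compound 1 reaches only the limit > 30000 nM.
Compound 2, `O=C(Nc1ccc(F)cc1)c1ccc2cccc(O)c2n1`: in this assay compound 2 likewise reaches only the limit > 30000 nM.

Both measured compounds share one core and differ only in the aryl group on the amide-type nitrogen. Neither gives a number: both sit at the limit of > 30000 nM in this assay, at which 2 of the 2 values shown sit, so compound 2 stands at a limit and nowhere more precise. Within the data shown here, the single measured step, a step that the two limits leave unreadable from compound 1 to compound 2, is therefore a change whose size cannot be read, and it gives no direction.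

Compound 3, `O=C(Nc1cccc(Br)c1)c1ccc2cccc(O)c2n1`, carries the change (3-bromophenyl in place of 4-fluorophenyl on an amide-type nitrogen). Among the measured compounds shown here, the one measured step bears on it only loosely, as it also exchanges the aryl group on that nitrogen, and it is unreadable. With no readable step behind it, no movement beyond the scatter is expected in this assay, and the step is estimated as a step that the limit leaves unreadable from compound 2 to compound 3. Compound 3 is therefore expected to come out again at the limit, with an estimate of 40000 nM and a range from 15000 nM to 120000 nM.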

Compound 3, half-maximal inhibitory concentration: > 30000 nM
Compound 3: no number, only a limit (the forecaster's own chance of this, stated with the estimate: 85%); the middle value lies beyond the limit too.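

Compound 3 also gives only a limit, and none of the steps linking compound 1, compound 2 and compound 3 can be read in this assay: the limit of > 30000 nM in this assay, at which 3 of the 3 values shown sit.

The compounds shown leave open whether changing the aryl group on the amide-type nitrogen alters cytotoxicity at all, and how the three would rank if each gave a number.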